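A second heteroaryl swap at the weak end of the series

The source may hold more compounds than are shown below. What is called first, only, known or untested is meant among the compounds shown, and "the series" means these compounds.

This account follows compound 2, `Cn1cc(CN2CCC[C@H](OCc3cc(Cl)cc(Cl)c3)[C@@H]2c2ccccc2)cn1`, into compound 3, `Clc1cc(Cl)cc(CO[C@H]2CCCN(Cc3ncc[nH]3)[C@H]2c2ccccc2)c1`, in an assay on isolated protein for activation of cGMP-dependent protein kinase 1 (Homo sapiens), read by ADP-Glo, with stated times of 120 min and 40 min; a lower number here means that less compound is needed, a higher number that more compound is needed for the effect. Going by the values given here, compound 2 gives 110000 nM, the only number recorded in this assay among the compounds described here. Compound 1, `Clc1cc(Cl)cc(CO[C@H]2CCCN(Cc3ccncc3)[C@H]2c2ccccc2)c1`, gives > 200000 nM, which is a limit of this assay rather than a number, as the limit of > 200000 nM in this assay, at which 1 of the 2 values shown sits, records. Among the compounds with values here, compound 2 thus stands alone as the one resolved value, with nothing firmer beside it to anchor the series.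

The change from compound 2 to compound 3 is 1H-imidazol-2-yl in place of 1-methyl-1H-pyrazol-4-yl on a saturated chain carbon bound to an amine nitrogen in a ring. Within the data shown here, the one measured step that bears on it is the earlier swap of one heteroaryl group for another on the same saturated chain carbon, an at least 1.8-fold lower number from compound 1 to compound 2 (0.25 log units; that floor lies within the scatter), whose floor lies within the scatter, so it shows no step beyond the scatter with certainty. From this the expected step in this assay is none beyond the scatter, in either direction, no change at the digits printed from compound 2 to compound 3 (within the scatter). Compound 3 is estimated at 110000 nM in this assay, between 40000 nM and 300000 nM, with a real chance that only a limit is reported.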

Compound 3, half-maximal effective concentration: 47000 nM
Compound 3: middle estimate off by 2.3-fold (0.37 log units), on the high side; measured number inside the range.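

In this assay, the place on a saturated chain carbon bound to an amine nitrogen in a ring now shows a step that clears the scatter, which the earlier swap could not show with certainty: a 2.3-fold lower number from compound 2 to compound 3 (0.37 log units; beyond the scatter), with 1H-imidazol-2-yl replacing 1-methyl-1H-pyrazol-4-yl. Set against pyridin-4-yl, the same group gives an at least 4.2-fold lower number from compound 1 to compound 3 (0.62 log units; beyond the scatter), so among the three compounds shown, which differ only in this group, compound 3 has the lowest number, and the choice of five- or six-membered aromatic group here does register in the read-out, though all three numbers remain high. The value of compound 1 is a limit of the assay and not a number, so this second step is only a floor: the limit of > 200000 nM in this assay, at which 1 of the 3 values shown sits.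

The swap from compound 2 to compound 3 alters the heavy-atom count and the donor and acceptor counts together, and these compounds cannot tell which of those differences goes with the step. As far as these compounds go, a 1H-pyrazol-4-yl or a 1-methyl-1H-imidazol-2-yl group at this place would bear on that question, and how far the number can fall at this place also stays open.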